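The compounds below may be only part of what the source reports. "The series", "measured", "known", "first", "only" and "open" are said of these compounds alone.

Of the compounds shown here, three sharing one core have been measured in a functional assay on HL-60 cells (Homo sapiens), read by calcium flux; a higher number here means that more compound is needed for the effect, a lower number that less compound is needed. Compound 1 `Cc1cc(Cc2ccsc2)c(=O)n(CC(=O)Nc2ccc(Br)cc2)n1` gives only the limit > 50000 nM and no number. Compound 2 `Cc1cc(Cc2cccnc2)c(=O)n(CC(=O)Nc2ccc(Br)cc2)n1` likewise gives the limit > 50000 nM. Compound 3 `Cc1cc(Cc2ccc(C#N)cc2)c(=O)n(CC(=O)Nc2ccc(Br)cc2)n1` also sits at the limit > 50000 nM, so where it stands is known only as a limit, and the limit of > 50000 nM in this assay, at which 3 of the 3 values shown sit, holds all three. The steps a step that the two limits leave unreadable from compound 1 to compound 2, a step that the two limits leave unreadable from compound 1 to compound 3 and a step that the two limits leave unreadable from compound 2 to compound 3 therefore show no readable size. Compound 4 `Cc1cc(N)c(=O)n(CC(=O)Nc2ccc(Br)cc2)n1` differs from compound 3 by amino in place of 4-cyanobenzyl on an aromatic carbon. The measured steps each exchange one aromatic group for another at the same saturated chain carbon, whereas here the whole 4-cyanobenzyl gives way to amino, and none of them offers a readable size to lean on. The expected step that the limit leaves unreadable from compound 3 to compound 4 is accordingly uncertain. Compound 4 is estimated at 60000 nM, between 15000 nM and 300000 nM, in this assay.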

Compound 4, half-maximal effective concentration: > 50000 nM
Compound 4: a limit, no number; the forecaster's own chance of this, stated with the estimate: 80%; the middle value is on the limit's open side.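

Compound 4 gives only a limit, so its steps from compound 1, compound 2 and compound 3 cannot be read: the limit of > 50000 nM in this assay, at which 4 of the 4 values shown sit. The compounds shown leave open how much of any of them this assay would need for the effect.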